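Trifluoromethyl in Place of Cyano: An Expected Shift

A few compounds are considered here, and "the series" means these few. Any claim that something is new, unique, unknown or untested is made for them only; others in the source may bear on it.

Of the compounds shown here, three have been measured in a functional assay on HL-60 cells (Homo sapiens) for cytotoxicity, read by luminescence and CellTiter-Glo, with a stated time of 3 days; a higher number here means a weaker inhibitor, a lower number a stronger inhibitor. Compound 1 `O=C(Nc1ccc(C(F)(F)F)cc1)c1ccc(Cl)cc1O` gives 630 nM. Compound 2 `N#Cc1ccc(NC(=O)c2ccc(F)cc2O)cc1` gives 1380 nM, the second highest of the three numbers, standing above compound 1 and well below compound 3. Compound 3 `N#Cc1ccc(NC(=O)c2ccc(-c3cccnc3)cc2O)cc1` gives 6660 nM. For the measured compounds named here, the only single-site step among the measured compounds, a 4.8-fold higher number from compound 2 to compound 3 (0.68 log units; beyond the scatter), concerns the other ring of the shared core and so bears only indirectly on the change considered here.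

Compound 4 `O=C(Nc1ccc(C(F)(F)F)cc1)c1ccc(F)cc1O` is not yet measured. It differs from compound 2 in one place: trifluoromethyl in place of cyano on an aromatic carbon. Going by the values given here, no measured pair isolates this change. Compound 1 carries the trifluoromethyl group but also a different halogen on the other ring, so its number offers only a hint. Since compound 1 gives 630 nM, compound 4 is expected to fall between the numbers of compound 2 and compound 1. The expected step is a 1.5-fold lower number from compound 2 to compound 4 (0.19 log units; within the scatter), a small change that may stay within the usual scatter. Compound 4 is estimated at 900 nM, with a range from 300 nM to 2700 nM.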

Compound 4, half-maximal inhibitory concentration: 680 nM
Beside the measured number, compound 4's estimate is 1.3-fold (0.12 log units) above it, within the range that was stated.
By their numbers in this assay, from the lowest: compounds 1 and 4 (each within the scatter of the next); then compound 2; then compound 3.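

For the compounds shown here, compound 4 supplies the first pair that isolates trifluoromethyl in place of cyano on this aromatic carbon, para to a large group: this assay shows a 2.0-fold lower number from compound 2 to compound 4 (0.31 log units; beyond the scatter), a modest step that lies beyond the scatter. It also isolates the halogen on the other ring, where fluoro in place of chloro gives a 1.1-fold higher number from compound 1 to compound 4 (0.03 log units; within the scatter), which places these two compounds within the scatter of each other. Nothing available here explains the size of either step. 

Going by these compounds, whether an amine, a carboxylic acid or a simple methyl at the same carbon would give a lower or higher number than trifluoromethyl remains open. So does whether fluoro and chloro would also fall within the scatter of each other in a compound that keeps the cyano group.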